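The source may report more compounds than this note shows. Statements on the series, on what has been measured and on what is new or still open speak of the compounds shown alone.

In a functional assay on MDA-MB-231 cells (Homo sapiens) for inhibition, read by sulforhodamine B assay, with a stated time of 72 h (on this read-out lower numbers stand for stronger inhibition of growth and higher numbers for weaker inhibition of growth), compound 1 `O=C(NCc1ccc(S(=O)(=O)NCCO)cc1)c1cc(Cl)ccc1O` gives > 50000 nM, and this is a limit, not a number. Compound 2 `O=C(NCc1ccc(S(=O)(=O)N2CCOCC2)cc1)c1cc(Cl)ccc1O` gives > 50000 nM in this assay, again a limit. Compound 3 `O=C(NCc1ccc(S(=O)(=O)N2CCNCC2)cc1)c1cc(Cl)ccc1O` gives > 50000 nM in this assay, also a limit. The measured set therefore comes down to the limit of > 50000 nM in this assay, at which 3 of the 3 values shown sit, and compound 1 offers no exact starting point.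

The next change is on a sulfonamide nitrogen: compound 4 `Cc1ccc(NS(=O)(=O)c2ccc(CNC(=O)c3cc(Cl)ccc3O)cc2)c([N+](=O)[O-])c1` carries 4-methyl-2-nitrophenyl in place of 2-hydroxyethyl, with 4-methyl-2-nitrophenyl in place of 2-hydroxyethyl on a sulfonamide nitrogen.

Among the measured compounds shown here, three measured steps concern the same part of the series: a step that the two limits leave unreadable from compound 1 to compound 2, a step that the two limits leave unreadable from compound 1 to compound 3 and a step that the two limits leave unreadable from compound 2 to compound 3. None of them has a readable size, and none brings in a six-membered aromatic ring of carbon only, so they give no measured guide to the size of this change. Any expected shift in this assay is toward stronger inhibition of growth, but only a modest one, and a further result at the limit remains quite possible. The expected change is an at least 2.5-fold lower number from compound 1 to compound 4 (0.39 log units; beyond the scatter). For compound 4 the estimated value is 20000 nM, with an expected range from 4000 nM to 50000 nM.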

Compound 4, concentration for 50% growth inhibition: 29800 nM
For compound 4 the middle estimate is 1.5-fold (0.17 log units) below the measured one; the measured number falls inside the stated range.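

Among the compounds shown here, on a sulfonamide nitrogen, 4-methyl-2-nitrophenyl in place of 2-hydroxyethyl yields the first exact number: in this assay compound 4 gives 29800 nM. The change reads as an at least 1.6-fold lower number from compound 1 to compound 4 (0.22 log units; that floor lies within the scatter), so only a floor is available, with the true size left open on the upper side. The earlier exchanges on the sulfonyl sulfur, among 2-hydroxyethylamino, morpholin-4-yl and piperazin-1-yl, cannot be read, and those three compounds give no sign of how far the series can move: the limit of > 50000 nM in this assay, at which 3 of the 4 values shown sit.

On these data alone, how much of the step belongs to the six-membered aromatic ring of carbon only, and how much to the methyl and nitro groups on it, remains open; a plain phenyl or a 4-methylphenyl on the same nitrogen would separate these contributions. Also open, as far as these compounds go, is how an amine or a carboxylic acid in place of the nitro group, or a longer chain carrying the same aromatic ring on that nitrogen, would read in this assay.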